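A few compounds are considered here, and "the series" means these few. Any claim that something is new, unique, unknown or untested is made for them only; others in the source may bear on it.

Measured so far:

Compound 1 `O=C1COc2ccc(-c3cnc4ccccc4c3)cc2N1C1CCCCC1` in a functional assay on HeLa cells (Homo sapiens) for antiproliferative activity, read by MTT assay, with a stated time of 72 h; on this read-out higher numbers stand for weaker inhibition and lower numbers for stronger inhibition: 19700 nM
Compound 2 `COc1ccc(N2C(=O)COc3ccc(-c4cnc5ccccc5c4)cc32)cc1` in this assay: a limit only, > 40000 nM
Compound 3 `COc1ccc(N2C(=O)COc3ccc(-c4cccc(NS(=O)(=O)c5ccc(F)cc5)c4)cc32)cc1` in this assay: 13200 nM

Compound 2 and compound 1 share one core and differ in a single place: cyclohexyl in place of 4-methoxyphenyl on an amide-type nitrogen in a ring. Compound 2 reaches only a limit in this assay, so the step can be given only as a floor: an at least 2.0-fold lower number from compound 2 to compound 1 (0.30 log units; that floor lies within the scatter). The size of that step rests on (the limit of > 40000 nM in this assay, at which 1 of the 3 values shown sits), and its floor lies within the usual scatter, so the true step may be larger but cannot be called small or large with confidence.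

Compound 3 carries a different core, and the difference between the two cores is not broken down here. Compound 3 and compound 1 sit within the scatter of each other in this assay, so no order between them is claimed.

Compound 4 `O=C1COc2ccc(-c3cccc(NS(=O)(=O)c4ccc(F)cc4)c3)cc2N1C1CCCCC1` is not yet measured. It differs from compound 3 in exactly the same way that compound 1 differs from compound 2: cyclohexyl in place of 4-methoxyphenyl on an amide-type nitrogen in a ring. The place is the same word for word, so this is the same change on a different core. Seen only once, and only as a floor, the earlier step of an at least 2.0-fold lower number from compound 2 to compound 1 (0.30 log units; that floor lies within the scatter) is the sole guide. On that basis the step from compound 3 to compound 4 is expected to be a 1.9-fold lower number from compound 3 to compound 4 (0.28 log units; within the scatter) in this assay, with wide uncertainty since the change has been seen on one core only. Compound 4 is therefore estimated at 7000 nM in this assay, expected to lie between 2500 nM and 20000 nM.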

Compound 4, half-maximal inhibitory concentration: 10800 nM
For compound 4 the middle estimate is 1.5-fold (0.19 log units) below the measured one, and the stated range covers the measured number.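

Replacing the 4-methoxyphenyl with cyclohexyl on the amide-type nitrogen in a ring gives, in this assay, a 1.2-fold lower number from compound 3 to compound 4 (0.09 log units; within the scatter), so on this core the swap cannot be said to change the result at all. Set beside the first case of the same swap, the comparison reads: the same change on two cores in this assay, an at least 2.0-fold lower number (0.30 log units; that floor lies within the scatter) from compound 2 to compound 1 and a 1.2-fold lower number (0.09 log units; within the scatter) from compound 3 to compound 4; the limit leaves it open whether they differ. This shows that neither core gives a step that can be read as beyond the usual scatter, but it does not show that the change carries over from one core to the other with the same size, nor that it fails to, for the earlier step rests on a value that is only a limit: the limit of > 40000 nM in this assay, at which 1 of the 4 values shown sits.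

The compounds shown leave open whether other groups on that same nitrogen, such as a methyl, a longer carbon chain or a chain ending in an amine, would give a clear step on either core. They also leave open how large the step really is on the core of compound 1, where compound 2 has a limit and not a number, and whether a third core would behave like these two.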